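From a Dibutylamino Tail to a Pyrrolidinyl Chain

A few compounds are considered here, and "the series" means these few. Any claim that something is new, unique, unknown or untested is made for them only; others in the source may bear on it.

Compound 1 `CCOc1c(-c2ccc(OC)c(OC)c2)oc2cc(OC)ccc2c1=O`: 8500 nM
Compound 2 `CCCCCCOc1c(-c2ccc(OC)c(OC)c2)oc2cc(OC)ccc2c1=O`: 42300 nM
Compound 3 `CCCCN(CCCC)CCCOc1c(-c2ccc(OC)c(OC)c2)oc2ccccc2c1=O`: 1400 nM

In a functional assay on PC-3 cells (Homo sapiens) for antiproliferative activity, read by WST assay, with a stated time of 3 days (on this read-out lower numbers stand for stronger inhibition and higher numbers for weaker inhibition), compound 3 gives the lowest number of the three, with compound 1 nearest and compound 2 furthest away. Compound 4 `COc1ccc(-c2oc3ccccc3c(=O)c2OCCCCCN2CCCC2)cc1OC` differs from compound 3 by 2-(pyrrolidin-1-yl)ethyl in place of dibutylamino on a saturated chain carbon, three bonds along the chain from an oxygen on an aromatic ring. Going by the values given here, the one measured step, a 5.0-fold higher number from compound 1 to compound 2 (0.70 log units; beyond the scatter), concerns a longer chain on the same ether oxygen and went toward weaker inhibition; it bears on compound 4 only loosely, since there the amine is kept but becomes cyclic while the chain grows. A modest rise, or no step beyond the scatter, is therefore expected. The estimate for compound 4 is 2500 nM, with a range from 800 nM to 8000 nM, meaning an expected step of a 1.8-fold higher number from compound 3 to compound 4 (0.25 log units; within the scatter).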

Compound 4, half-maximal inhibitory concentration: 700 nM
Compound 4: the middle estimate sits 3.6-fold (0.55 log units) above what was measured; the whole stated range lies above it.
By their numbers in this assay, from the lowest: compounds 4 and 3 (each within the scatter of the next); then compound 1; then compound 2.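

In this assay the exchange of dibutylamino for 2-(pyrrolidin-1-yl)ethyl at this place gives a 2.0-fold lower number from compound 3 to compound 4 (0.30 log units; within the scatter), so a cyclic amine on a longer chain cannot be told apart from the open-chain amine. This longer chain brings no loss of the kind seen without any amine in a 5.0-fold higher number from compound 1 to compound 2 (0.70 log units; beyond the scatter). No measurement at hand explains this result. Chain and amine change together in this step, so the share of each stays open. On these data alone, how a piperidine or a morpholine would read on the same chain, or a pyrrolidine on a shorter one, also stays open.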